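Cyclohexyl carboxamide on the shared core

This account rests on a few compounds, and the source may have more. Where it says the series, first, only, none or still open, it means among the compounds named here.

The three measured compounds share one core and differ only in the group on the carbonyl carbon. In a functional assay on cells for positive allosteric modulation of metabotropic glutamate receptor 5 (Rattus norvegicus), read by calcium flux (on this read-out lower numbers stand for an effect already at smaller amounts and higher numbers for an effect only at larger amounts of compound), compound 1 `O=C(Nc1cc(-c2ccccc2)nn1-c1ccccc1)c1cccc(C(F)(F)F)c1` gives 228 nM, compound 2 `O=C(Nc1cc(-c2ccccc2)nn1-c1ccccc1)c1ccc([N+](=O)[O-])cc1` gives 10.7 nM, and compound 3 `Cc1ccc(C(=O)Nc2cc(-c3ccccc3)nn2-c2ccccc2)cc1C` gives 20 nM. Compound 3 thus stands second highest of the three numbers, close to compound 2 and far from compound 1. The steps seen so far are a 21-fold lower number from compound 1 to compound 2 (1.33 log units; beyond the scatter), an 11-fold lower number from compound 1 to compound 3 (1.06 log units; beyond the scatter) and a 1.9-fold higher number from compound 2 to compound 3 (0.27 log units; within the scatter); each exchanges one six-membered aromatic ring of carbon only for another, and two of them are large.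

Compound 4 `O=C(Nc1cc(-c2ccccc2)nn1-c1ccccc1)C1CCCCC1` carries cyclohexyl in place of 3,4-dimethylphenyl on a carbonyl carbon. Among the measured compounds shown here, no measured step bears directly on this change: every step so far keeps an aromatic ring on the carbonyl carbon, and even those exchanges already span the full gap between compound 1 and compound 2. The move to a non-aromatic ring is judged a larger departure than any measured step, so for compound 4 a higher number in this assay is expected, by a 10-fold higher number from compound 3 to compound 4 (1.00 log units; beyond the scatter). The estimate for compound 4 is 200 nM, within 30 nM to 1500 nM.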

Compound 4, half-maximal effective concentration: > 10000 nM
Compound 4 ended at the assay's limit (the forecaster's own chance of this, stated with the estimate: 25%); middle value at least 50-fold (1.69 log units) from the limit.
By their numbers in this assay, from the lowest: compounds 2 and 3 (each within the scatter of the next); then compound 1. At a limit, above all of these: compound 4.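

For compound 4, the > 10000 nM in this assay is a limit of the assay and not a number. Once the aromatic ring on the carbonyl carbon gives way to cyclohexyl, the steps read an at least 500-fold higher number from compound 3 to compound 4 (2.69 log units; beyond the scatter), an at least 930-fold higher number from compound 2 to compound 4 (2.97 log units; beyond the scatter) and an at least 43-fold higher number from compound 1 to compound 4 (1.64 log units; beyond the scatter). The earlier compounds shown here showed only that the choice of aromatic ring at this position moves the number; compound 4 adds that a six-membered non-aromatic ring of carbon only ends at the limit, with compounds 1, 2 and 3 all reading lower and none of the four going against this.

Cyclohexyl is the only non-aromatic group shown here, so the data cannot tell whether this result holds for non-aromatic rings generally or for this ring alone. Going by these compounds, how a pyridine ring, a cyclopropyl group or a benzyl group on the carbonyl carbon would read in this assay remains open.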